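The compounds below may be only part of what the source reports. "The series", "measured", "known", "first", "only" and "open" are said of these compounds alone.

Of the compounds shown here, three built on one shared core have been tested in a functional assay on MOLT-4 cells (Homo sapiens); on this read-out lower numbers stand for stronger inhibition and higher numbers for weaker inhibition. Compound 1 `NC(=O)c1nn([C@@H]2O[C@H](CO)[C@@H](O)[C@H]2O)cc1I` gives 9100 nM, and compound 2 `COC(=O)c1nn([C@@H]2O[C@H](CO)[C@@H](O)[C@H]2O)cc1I` gives 900 nM, the lowest number obtained so far. Compound 3 `C#Cc1cn([C@@H]2O[C@H](CO)[C@@H](O)[C@H]2O)nc1C(N)=O` gives > 300000 nM, which is a limit of the assay and not a number.

Still unmeasured is compound 4 `Cc1noc(-c2nn([C@@H]3O[C@H](CO)[C@@H](O)[C@H]3O)cc2I)n1`, which differs from compound 2 by having 3-methyl-1,2,4-oxadiazol-5-yl in place of methoxycarbonyl on an aromatic carbon, while the iodo group stays: 3-methyl-1,2,4-oxadiazol-5-yl in place of methoxycarbonyl on an aromatic carbon. Within the data shown here, two measured steps bear on this change. The closer one is a 10-fold lower number from compound 1 to compound 2 (1.00 log units; beyond the scatter), where methoxy replaces amino on a carbonyl carbon. It shows that a change within the group at this same place can shift this assay modestly. The other, an at least 32-fold higher number from compound 1 to compound 3 (1.51 log units; beyond the scatter), is large, but it replaces the iodo group that compound 4 keeps, so it says little here. Among the measured compounds shown here, no measured compound carries a ring at this place, which leaves the direction uncertain. A modest move towards a higher number is expected, the estimated change being a 3.3-fold higher number from compound 2 to compound 4 (0.52 log units; beyond the scatter). For compound 4 the expected value is 3000 nM, with an estimated range from 500 nM to 30000 nM.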

Compound 4, half-maximal inhibitory concentration: 3000 nM
Compound 4: middle estimate and measured number agree at the digits printed; measured number inside the range.
By their numbers in this assay, from the lowest: compound 2; then compound 4; then compound 1. At a limit, above all of these: compound 3.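

In this assay, a five-membered aromatic ring with 3 hetero atoms can stand at this place on the shared core, with the iodo group kept, and a measurable number remains: putting 3-methyl-1,2,4-oxadiazol-5-yl in place of methoxycarbonyl gives a 3.3-fold higher number from compound 2 to compound 4 (0.52 log units; beyond the scatter), while putting it in place of carbamoyl gives a 3.0-fold lower number from compound 1 to compound 4 (0.48 log units; beyond the scatter). The earlier compounds had shown only two carbonyl groups at this place, and the new ring now falls between them, with both steps beyond the scatter. Nothing in the data given accounts for this order.

On these data alone, it remains open how a carboxylic acid, a nitrile, or the same ring with an ethyl group in place of its methyl would read at this place. As far as these compounds go, compound 3, with ethynyl in place of iodo, gives > 300000 nM, which is a limit of the assay and not a number, and whether that exchange would act alike with methoxycarbonyl or 3-methyl-1,2,4-oxadiazol-5-yl in place of carbamoyl also stays open.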